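A few compounds are considered here, and "the series" means these few. Any claim that something is new, unique, unknown or untested is made for them only; others in the source may bear on it.

Series on the shared core of compound 1 `Cc1ccc2c(NCc3ccc(NC(=O)C4CCN(Cc5ccco5)CC4)cc3)nc(N(C)C)nc2c1`, varied at the saturated chain carbon bound to an amine nitrogen in a ring. In a functional assay on SV5A8 cells (Homo sapiens) for cytotoxicity (a higher number here means a weaker inhibitor, a lower number a stronger inhibitor), compound 1 gives only a limit, > 20000 nM. Compound 2 `Cc1ccc2c(NCc3ccc(NC(=O)C4CCN(C)CC4)cc3)nc(N(C)C)nc2c1` likewise reaches a limit in this assay, > 17300 nM. Compound 3 `Cc1ccc(CN2CCC(C(=O)Nc3ccc(CNc4nc(N(C)C)nc5cc(C)ccc45)cc3)CC2)cc1` gives a limit as well in this assay, > 4150 nM. Compound 3 thus stands at a limit, as do the other two values shown, and the steps a step that the two limits leave unreadable from compound 1 to compound 2, a step that the two limits leave unreadable from compound 1 to compound 3 and a step that the two limits leave unreadable from compound 2 to compound 3 are all unreadable in size, with the limit of > 17300 nM in this assay, at which 1 of the 3 values shown sits, the limit of > 20000 nM in this assay, at which 1 of the 3 values shown sits, and the limit of > 4150 nM in this assay, at which 1 of the 3 values shown sits, marking where each value sits. Compound 4 `Cc1ccc2c(NCc3ccc(NC(=O)C4CCN(Cc5ccc(Cl)cc5)CC4)cc3)nc(N(C)C)nc2c1` differs from compound 3 by chloro in place of methyl on an aromatic carbon. Among the measured compounds shown here, none of the measured steps reads as a number, so no measured basis exists for the size or direction of this change in this assay; the expectation is a step that the limit leaves unreadable from compound 3 to compound 4, that is none beyond the scatter, with a further limit the most likely outcome. Compound 4 is estimated at 10000 nM in this assay, within 3000 nM to 30000 nM.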

Compound 4, half-maximal inhibitory concentration: > 3180 nM
Compound 4 gave a limit, no number (the forecaster's own chance of this, stated with the estimate: 70%); the middle value is on the limit's open side.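

Among the compounds shown here, compound 4 gives only a limit in this assay, so no step linking it to compound 1, compound 2 or compound 3 can be read. The compounds shown leave open the size and direction of any effect of exchanging hydrogen, furan-2-yl, 4-methylphenyl and 4-chlorophenyl at this position.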